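The compounds below may be only part of what the source reports. "The series", "measured", "known", "first", "only" and "open" are said of these compounds alone.

Measured compounds:
Compound 1, `COc1ccc(C2=NOC(c3ccc(C)cc3)C2S(=O)(=O)CC2=NCCO2)cc1`, 65.9%.
Compound 2, `COc1ccc(C2=NOC(c3ccc(C)cc3)C2S(=O)(=O)CC2=NCCS2)cc1`, 54.1%.
Compound 3, `O=S(=O)(CC1=NCCS1)C1=NNCC1c1ccc(Cl)cc1`, "not active" (no number reported).

The study compares three measured compounds in a functional assay, read by Griess assay, with a stated time of 150 min, tested at 75 ug/mL (on this read-out lower numbers stand for a weaker effect and higher numbers for a stronger effect at the one concentration tested), and sets one further compound, compound 4, `O=S(=O)(CC1=NCCO1)C1=NNCC1c1ccc(Cl)cc1`, next to them. Compound 1 and compound 2 share a core and differ in one place: a group of 5 heavy atoms (3 carbon, 1 nitrogen, 1 oxygen; one five-membered non-aromatic ring with 2 hetero atoms) in place of a group of 5 heavy atoms (3 carbon, 1 nitrogen, 1 sulfur; one five-membered non-aromatic ring with 2 hetero atoms), on a saturated chain carbon bound to a sulfonyl sulfur. That step is measured, and it is a number 11.8 percentage points higher from compound 2 to compound 1 (beyond the scatter). Compound 3 rests on a different core, and the difference between the two cores is not broken down here. In this assay compound 3 is reported as "not active" (no number reported), without a number.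

Compound 4 stands to compound 3 as compound 1 stands to compound 2: a group of 5 heavy atoms (3 carbon, 1 nitrogen, 1 oxygen; one five-membered non-aromatic ring with 2 hetero atoms) in place of a group of 5 heavy atoms (3 carbon, 1 nitrogen, 1 sulfur; one five-membered non-aromatic ring with 2 hetero atoms), on a saturated chain carbon bound to a sulfonyl sulfur. The place is the same in both pairs, so this is the same change made on the other core, and among the compounds shown it occurs twice in all. Only one of the two occurrences is measured. On that one the step is modest and beyond the scatter, as a number 11.8 percentage points higher from compound 2 to compound 1 (beyond the scatter) shows, but it is counted from a starting point that already gives a clear read-out, whereas compound 3 gives none. A change of that size added to an inactive starting point would still leave compound 4 near the bottom of the scale. Compound 4 is therefore expected to give about 12% in this assay, with a range from 0% to 30%, and it is as likely as not that only a limit is reported.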

Compound 4, a percentage reported as activity, at one concentration (the size of the read-out at that concentration, not a potency): "not active" (no number reported)
No number was reported for compound 4; no gap can be computed for the estimate.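

Compound 3 and compound 4 are both reported as not active in this assay without a number, so no new step can be read from this pair. The compounds shown leave open whether the change from the sulfur-containing ring to the oxygen-containing ring has any effect on the core of compound 3. No measured property here bears on this result.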